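The compounds below may be only part of what the source reports. "The series", "measured", "known", "first", "only" and "open" are said of these compounds alone.

Series notes, antagonism at a functional assay on CHO cells for antagonist activity at prostaglandin E2 receptor EP3 subtype (Homo sapiens), read by cAMP accumulation; a lower number here means a stronger inhibitor, a higher number a weaker inhibitor. Compound 1 `CCn1ncc2c(F)cc(-c3ccc(C(CC)(CC)c4nnc(C)[nH]4)c(=O)[nH]3)cc21` gives 90 nM; compound 2 `CC(C)C(c1ccc(-c2ccc3cccc(F)c3c2)[nH]c1=O)N1CCNC1=O` gives 28 nM; compound 3 `CC(C)C(/C=C1\CCNC1=O)c1ccc(-c2ccc3cccc(F)c3c2)[nH]c1=O` gives 8.7 nM, the lowest of the three, with compound 2 nearest and compound 1 furthest. Among the measured compounds shown here, the one single-point step on record is a 3.2-fold lower number from compound 2 to compound 3 (0.51 log units; beyond the scatter). Compound 4 `CC(C)C(c1ncco1)c1ccc(-c2ccc3cccc(F)c3c2)[nH]c1=O` differs from compound 3 by a group of 5 heavy atoms (3 carbon, 1 nitrogen, 1 oxygen; one five-membered aromatic ring with 2 hetero atoms) in place of a group of 7 heavy atoms (5 carbon, 1 nitrogen, 1 oxygen; one five-membered non-aromatic ring with 1 hetero atom), on a saturated chain carbon bound to an aromatic carbon and a saturated chain carbon. For the measured compounds named here, only the step from compound 2 to compound 3 bears on this; it shows that the group on this saturated chain carbon moves the number modestly, and compound 4 carries a ring with 2 hetero atoms as compound 2 does, so a return toward that level is expected. Compound 4 is estimated at 25 nM, range 8 nM to 75 nM, a step of a 2.9-fold higher number from compound 3 to compound 4 (0.46 log units; beyond the scatter) expected.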

Compound 4, half-maximal inhibitory concentration: 64 nM
Beside the measured number, compound 4's estimate is 2.6-fold (0.41 log units) below it, within the range that was stated.
By their numbers in this assay, from the lowest: compound 3; then compound 2; then compounds 4 and 1 (each within the scatter of the next).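

Among the compounds shown here, the group on this saturated chain carbon carries more weight than the earlier step showed: a 7.4-fold higher number from compound 3 to compound 4 (0.87 log units; beyond the scatter) is the largest change at this place so far, and it leaves 1,3-oxazol-2-yl with the highest number of the three groups compared here. A ring with 2 hetero atoms does not by itself set the level, as a 2.3-fold higher number from compound 2 to compound 4 (0.36 log units; beyond the scatter) separates 1,3-oxazol-2-yl from 2-oxoimidazolidin-1-yl. No measurement at hand accounts for this order.
Still open, from the compounds shown here alone, is where an open-chain amide or a primary amine on this carbon would fall relative to these three groups.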